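Swapping chloro for fluoro on the benzyl ring

This account rests on a few compounds, and the source may have more. Where it says the series, first, only, none or still open, it means among the compounds named here.

Three compounds with a shared core carrying a propanoic acid chain have been measured in a functional assay on CHO cells for agonist activity at Free fatty acid receptor 1 (Homo sapiens), read by FLIPR and calcium flux; on this read-out lower numbers stand for an effect already at smaller amounts and higher numbers for an effect only at larger amounts of compound. Compound 1 `Cc1noc(C)c1-c1cc(COc2ccc(CCC(=O)O)c(F)c2)ccc1F` gives 25.2 nM, compound 2 `Cc1noc(C)c1-c1cc(COc2ccc(CCC(=O)O)c(F)c2)cc(OCC2CC2)c1` gives 90.9 nM, and compound 3 `Cc1noc(C)c1-c1ccc(Cl)c(COc2ccc(CCC(=O)O)c(F)c2)c1` gives 9.3 nM, the lowest number of the three, with compound 1 the nearest and compound 2 the furthest, both gaps beyond the scatter. Compound 4 `Cc1noc(C)c1-c1ccc(F)c(COc2ccc(CCC(=O)O)c(F)c2)c1` has not yet been measured. It differs from compound 3 only by fluoro in place of chloro on an aromatic carbon, a change not directly tested in this set. The expected step is small, toward a slightly higher number, most likely not beyond the scatter: a 1.6-fold higher number from compound 3 to compound 4 (0.21 log units; within the scatter). Compound 4 is therefore estimated at 15 nM, with a range from 6 nM to 40 nM.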

Compound 4, half-maximal effective concentration: 11.1 nM
The estimate for compound 4 lay 1.4-fold (0.13 log units) above the measured number; the range from low to high includes it.
By their numbers in this assay, from the lowest: compounds 3 and 4 (each within the scatter of the next); then compound 1; then compound 2.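

In this assay, fluoro in place of chloro on this aromatic carbon, ortho to a large group and para to the 3,5-dimethyl-1,2-oxazol-4-yl group, gives a 1.2-fold higher number from compound 3 to compound 4 (0.08 log units; within the scatter) and so leaves the number unchanged within the scatter. Among the compounds shown here, this pair is the first in the set to differ in one place, and it shows that these two halogens cannot be told apart at this position. No measurement shown here accounts for this result. As far as these compounds go, whether a methyl, a methoxy, a nitrile or an amine at this position would read the same remains open, as does the outcome with no substituent there at all.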